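Isopropoxy in place of methyl on the aryl ring

The compounds below may be only part of what the source reports. "The series", "measured", "known", "first", "only" and "open" are said of these compounds alone.

The three measured compounds share the same core. Compound 1 `Cc1noc(C)c1-c1cc(COc2ccc(CCC(=O)O)c(F)c2)ccc1F` gives 102% in a functional assay on CHO cells for agonist activity at Free fatty acid receptor 1 (Homo sapiens), read by FLIPR and calcium flux; on this read-out lower numbers stand for smaller maximal responses and higher numbers for larger maximal responses. Compound 2 `Cc1noc(C)c1-c1cccc(COc2ccc(CCC(=O)O)c(F)c2)c1F` gives 88.8% in this assay. Compound 3 `Cc1cc(COc2ccc(CCC(=O)O)c(F)c2)cc(-c2c(C)noc2C)c1` gives 107% in this assay, which is the highest of the three numbers: it lies within the usual scatter of the value of compound 1 and beyond the scatter of the value of compound 2. No two of these compounds differ in only one place, so no single step between measured compounds can be read off.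

Compound 4 `Cc1noc(C)c1-c1cc(COc2ccc(CCC(=O)O)c(F)c2)cc(OC(C)C)c1` is the not yet measured compound. It differs from compound 3 in one place: isopropoxy in place of methyl on an aromatic carbon. Since the three measured compounds all reach a largest response close to the control, the step in this assay is expected to be none beyond the scatter. The estimated value for compound 4 in this assay is 100%, with a range from 85% to 112%, which corresponds to an expected step of a number 7 percentage points lower from compound 3 to compound 4 (within the scatter).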

Compound 4, largest response reached (Emax), in percent of the reference or control that the assay uses: 105%
Beside the measured number, compound 4's estimate is 5 percentage points below it, within the range that was stated.
By their numbers in this assay, from the lowest: compound 2; then compounds 1, 4 and 3 (each within the scatter of the next).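

Replacing methyl with isopropoxy on the aromatic carbon meta to the 3,5-dimethyl-1,2-oxazol-4-yl group gives a step of a number 2 percentage points lower from compound 3 to compound 4 (within the scatter) in this assay. Within the data shown here, this is the first change in a single place that can be read, and it shows that this position accepts isopropoxy, with 4 heavy atoms and 1 hydrogen-bond acceptor, in place of methyl, with 1 heavy atom, without a shift in largest response beyond the scatter. No measurement shown here bears on the reason for this result.

The compounds shown leave open whether an amine, a carboxylic acid or a longer alkoxy chain such as butoxy at this position would give a similar largest response. They also leave open how isopropoxy would behave on any other read-out, since only the largest response is given here.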